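The source may hold more compounds than are shown below. What is called first, only, known or untested is meant among the compounds shown, and "the series" means these compounds.

Measured compounds:
- compound 1 `CCCCn1cnc2c(NCc3ccc(C(=O)Nc4ccccc4N)cc3)nc(Cl)nc21`: 6.8%
- compound 2 `Nc1ccccc1NC(=O)c1ccc(Cn2cnc3c(NCc4ccccc4)nc(Cl)nc32)cc1`: 7.55%
- compound 3 `CC(C)n1cnc2c(NCc3ccc(C(=O)Nc4ccccc4N)cc3)nc(Cl)nc21`: 63.8%

Of the compounds shown here, three sharing one core have been tested in a functional assay on HepG2 cells (Homo sapiens) for antiproliferative activity, read by CCK-8 assay, with a stated time of 72 h, tested at 2 uM; on this read-out higher numbers stand for a stronger effect at the one concentration tested and lower numbers for a weaker effect. Compound 3 stands highest of the three: compound 2 is nearer to it, with a number lower by more than the scatter, and compound 1 is furthest, again lower by more than the scatter. Among the compounds with values here, the one step that can be followed within a single change is the one from compound 1 to compound 3, where isopropyl replaced butyl on an aromatic nitrogen and the read-out in this assay rose by a number 57 percentage points higher from compound 1 to compound 3 (beyond the scatter), a large step.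

Compound 4 `CCCn1cnc2c(NCc3ccc(C(=O)Nc4ccccc4N)cc3)nc(Cl)nc21` is not yet measured. It differs from compound 3 by propyl in place of isopropyl on an aromatic nitrogen. Within the data shown here, the step from compound 1 to compound 3 bears on this change, since it also alters the chain on the same aromatic nitrogen, but it compared a four-carbon chain with a branched three-carbon one; no measured pair compares a branched chain with a straight chain of the same length. Since a straight propyl lies between the two chains already seen, the account expects a number for compound 4 somewhat below that of compound 3, by about a number 28.8 percentage points lower from compound 3 to compound 4 (beyond the scatter), with wide uncertainty. The estimate for compound 4 in this assay is 35%, in a range from 8% to 65%.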

Compound 4, a percentage reported as inhibition, at one concentration (the size of the read-out at that concentration, not a potency): 12.4%
Compound 4: the middle estimate sits 22.6 percentage points above what was measured; measured number inside the range.
By their numbers in this assay, from the lowest: compounds 1, 2 and 4 (each within the scatter of the next); then compound 3.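

In this assay, the record gives a number 51.4 percentage points lower from compound 3 to compound 4 (beyond the scatter), and this shows that on this aromatic nitrogen the arrangement of the chain matters and not only its make-up, as isopropyl and propyl hold the same atoms, joined differently. The straight chains do not separate in the same way: hydrogen in place of methyl on the chain carbon leaves a number 5.6 percentage points higher from compound 1 to compound 4 (within the scatter), so propyl and butyl read alike, and among these compounds the high read-out goes with the branched isopropyl alone. Nothing available here explains why the branched and straight chains part so sharply.

Going by these compounds, it remains open whether any branching on this nitrogen carries the effect or only isopropyl does, a question that cyclopropyl, sec-butyl or tert-butyl on the same nitrogen would address, and whether a shorter chain such as ethyl or methyl would read like propyl or like isopropyl. All of these numbers also come from a single concentration, so they give the size of the effect there and leave the potency of these compounds unknown.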